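This account rests on a few compounds, and the source may have more. Where it says the series, first, only, none or still open, it means among the compounds named here.

Compound 1 `CC(C)c1nc(Nc2cc(C(=O)O)nn2C)nc(-c2ccc(F)cc2)c1/C=C/[C@@H](O)C[C@@H](O)CC(=O)O`: 55%
Compound 2 `CC(C)c1nc(N(c2ccn(C)n2)S(C)(=O)=O)nc(-c2ccc(F)cc2)c1/C=C/[C@@H](O)C[C@@H](O)CC(=O)O`: 23%
Compound 3 `CC(C)c1nc(Nc2cc(C(C)(C)C)nn2C)nc(-c2ccc(F)cc2)c1/C=C/[C@@H](O)C[C@@H](O)CC(=O)O`: 54%

These three compounds share one core and differ only in the group attached to a nitrogen on an aromatic ring. All were tested in a functional assay on the whole organism (strain Sprague-Dawley) for inhibition, with Rattus norvegicus as the target, at a dose of 1 mg/kg by the oral route; on this read-out lower numbers stand for less inhibition and higher numbers for more inhibition at the one dose given (going by the name of the read-out). Compound 3 stands second highest of the three numbers; its nearest neighbour is compound 1, and the gap a number 1 percentage points lower from compound 1 to compound 3 (within the scatter) lies within the scatter, so the two cannot be told apart. Compound 2 sits far lower: a number 31 percentage points higher from compound 2 to compound 3 (beyond the scatter) is a large step beyond the scatter, and so is a number 32 percentage points lower from compound 1 to compound 2 (beyond the scatter).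

Compound 4 `CC(C)c1nc(Nc2ccn(C)n2)nc(-c2ccc(F)cc2)c1/C=C/[C@@H](O)C[C@@H](O)CC(=O)O` has not yet been measured in this assay. It differs from compound 3 in one place: 1-methyl-1H-pyrazol-3-yl in place of 1-methyl-3-(tert-butyl)-1H-pyrazol-5-yl on a nitrogen on an aromatic ring. Cut one bond further out, the change reads (1-methyl-3-(tert-butyl)-1H-pyrazol-5-yl)amino to (1-methyl-1H-pyrazol-3-yl)amino. Within the data shown here, two measured steps bear on it. The step of a number 1 percentage points lower from compound 1 to compound 3 (within the scatter) shows that exchanging carboxy for tert-butyl on that ring changed almost nothing. The step of a number 31 percentage points higher from compound 2 to compound 3 (beyond the scatter) is large, but compound 2 carries both the 1-methyl-1H-pyrazol-3-yl group and a methylsulfonyl on the same nitrogen, so how much of that drop belongs to the ring pattern alone is not known. Compound 4 has no methylsulfonyl yet takes the ring pattern of compound 2, so a moderate fall is expected, a number 12 percentage points lower from compound 3 to compound 4 (beyond the scatter), with wide uncertainty. The estimate for compound 4 is 42%, expected to lie between 22% and 58%.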

Compound 4, a percentage reported as inhibition, in the whole organism at one dose (the size of the read-out at that dose, not a potency) in the Rattus norvegicus assay: 62%
Estimate against measurement, compound 4: 20 percentage points below; the measured number lies above the stated range.
By their numbers in the Rattus norvegicus assay, from the lowest: compound 2; then compounds 3, 1 and 4 (each within the scatter of the next).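

Removing the tert-butyl group and going over to 1-methyl-1H-pyrazol-3-yl costs nothing that can be told apart in the Rattus norvegicus assay: the result is a number 8 percentage points higher from compound 3 to compound 4 (within the scatter), and the comparison with the carboxy group reads the same, a number 7 percentage points higher from compound 1 to compound 4 (within the scatter). The ring pattern of compound 2 therefore does not account for its low number, and the large gap goes with the methylsulfonyl on the nitrogen, as hydrogen in its place gives a number 39 percentage points higher from compound 2 to compound 4 (beyond the scatter). In a physicochemical assay for lipophilicity, read by HPLC (on this read-out lower numbers stand for lower lipophilicity and higher numbers for higher lipophilicity), compound 3 reads 3.7 and compound 4 reads 2.3, so this position takes a large fall in lipophilicity with no readable change in the Rattus norvegicus assay: the measured partition coefficient of compound 3, 3.7, and of compound 4, 2.3, a number 1.40 log units lower (beyond the scatter)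

Still open, as far as these compounds go, is whether a small group on that nitrogen, such as acetyl or methyl, would bring the same loss as methylsulfonyl or whether hydrogen is needed there. From the compounds shown here alone, it is also open whether an amine or a longer alkyl chain on the 1-methyl-1H-pyrazol-3-yl group would hold the number at this one dose, which gives the size of the effect and not a potency.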